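From a Methoxy Group to a Pyridinone: Cytotoxicity Outlook

The source may hold more compounds than are shown below. What is called first, only, known or untested is meant among the compounds shown, and "the series" means these compounds.

Compound 1 `OC[C@H]1O[C@@H](n2cnc3c(CN4CCCCC4)ncnc32)[C@H](O)[C@@H]1O` and compound 2 `COCc1ncnc2c1ncn2[C@@H]1O[C@H](CO)[C@@H](O)[C@H]1O` share one core and differ only at a saturated chain carbon bound to an aromatic carbon. In a functional assay on Huh-7 cells (Homo sapiens) for cytotoxicity, read by MTT assay, with a stated time of 3 days (on this read-out higher numbers stand for lower toxicity in this test and lower numbers for higher toxicity in this test), compound 1 gives 87000 nM. Compound 2 reaches only a limit of this assay, > 100000 nM, so no exact number is known for it (the limit of > 100000 nM in this assay, at which 1 of the 2 values shown sits). The step of an at least 1.1-fold higher number from compound 1 to compound 2 (0.06 log units; that floor lies within the scatter) lies within the scatter. Compound 3 `O=c1ccccn1Cc1ncnc2c1ncn2[C@@H]1O[C@H](CO)[C@@H](O)[C@H]1O` carries a group of 7 heavy atoms (5 carbon, 1 nitrogen, 1 oxygen; one six-membered aromatic ring with 1 hetero atom) in place of a group of 2 heavy atoms (1 carbon, 1 oxygen; no ring), on a saturated chain carbon bound to an aromatic carbon. Within the data shown here, no measured step covers this new group; the only change seen at the same carbon was small, so no step beyond the scatter is expected. Compound 3 is therefore expected to give 100000 nM, between 40000 nM and 300000 nM, an expected step of a number no higher from compound 2 to compound 3 (the limit leaves the size open).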

Compound 3, half-maximal cytotoxic concentration: > 100000 nM
Compound 3 ended at the assay's limit; the forecaster's own chance of this, stated with the estimate: 65%; the middle value lies on the limit itself.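

Compound 3 shows that a group with a six-membered aromatic ring on this saturated chain carbon bound to an aromatic carbon leaves the read-out at the limit, as methoxy did: the limit of > 100000 nM in this assay, at which 2 of the 3 values shown sit.

Set against the piperidin-1-yl group, the new group gives an at least 1.1-fold higher number from compound 1 to compound 3 (0.06 log units; that floor lies within the scatter). The step between compound 2 and compound 3 cannot be read.

Open, as far as these compounds go, is whether any group at this carbon gives a number clearly lower in this assay. A primary amine or a carboxylic acid on the same carbon could show whether the read-out moves beyond the scatter.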